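This account rests on a few compounds, and the source may have more. Where it says the series, first, only, none or still open, it means among the compounds named here.

Measured in a functional assay on MDA-MB-435 cells (Homo sapiens) for cytotoxicity, read by MTT assay, with a stated time of 72 h; on this read-out lower numbers stand for stronger inhibition and higher numbers for weaker inhibition:
Compound 1 `O=C(NCc1ccc(F)cc1)c1nc(Br)c2cccnc2c1NCc1ccc(F)cc1`: > 20000 nM (a limit)
Compound 2 `N[C@H]1CC[C@H](NC(=O)c2nc(Br)c3cccnc3c2NCc2ccc(F)cc2)CC1`: 6600 nM

Compound 1 stands at the limit of > 20000 nM in this assay, at which 1 of the 2 values shown sits, which is a limit and not a number. Compound 3 `O=C(NCc1ccc(F)cc1)c1nc(Br)c2cccnc2c1N1CCNCC1` retains the core of compound 1 and changes one substituent, on an aromatic carbon para to a bromo group: piperazin-1-yl in place of (4-fluorobenzyl)amino on an aromatic carbon. Going by the values given here, only one measured step bears on this change, and only indirectly: an at least 3.0-fold lower number from compound 1 to compound 2 (0.48 log units; beyond the scatter). That step lies beyond the scatter, but it sits on an amide-type nitrogen and not on the aromatic carbon. What it shares with the new change is that a 4-fluorobenzyl group leaves and a six-membered non-aromatic ring enters. On that thin basis, a step of similar size towards lower numbers is expected in this assay, with compound 2 at 6600 nM as the nearest guide. Compound 3 could still end up reported only as a limit. The expected step is an at least 2.8-fold lower number from compound 1 to compound 3 (0.45 log units; beyond the scatter). For compound 3 the estimate is 7000 nM, with an expected range from 2000 nM to 22000 nM.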

Compound 3, half-maximal inhibitory concentration: 8000 nM
Compound 3: middle estimate off by 1.1-fold (0.06 log units), on the low side; measured number inside the range.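

In this assay, replacing (4-fluorobenzyl)amino with piperazin-1-yl on the aromatic carbon para to a bromo group gives an at least 2.5-fold lower number from compound 1 to compound 3 (0.39 log units; beyond the scatter). Going by these compounds alone, the earlier compounds showed a step only on the amide-type nitrogen, so this is the first reading for this position, and it shows that a change here also lifts a compound of this series from a limit to a measured number, with one of the two 4-fluorobenzyl groups of compound 1 gone in each case. The full size of the step cannot be read, because compound 1 has only a limit and not a number: the limit of > 20000 nM in this assay, at which 1 of the 3 values shown sits.

The compounds shown leave open whether the piperazin-1-yl ring as a whole matters on this carbon or only its second nitrogen, a question that morpholin-4-yl or an open-chain amine in the same place would address. They also leave open what piperazin-1-yl on this carbon and 4-aminocyclohexyl on the amide-type nitrogen would give together on the shared core.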